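This account rests on a few compounds, and the source may have more. Where it says the series, first, only, none or still open, it means among the compounds named here.

In a functional assay on CCRF-CEM cells (Homo sapiens) for antiproliferative activity, read by MTT assay, with a stated time of 72 h (a higher number here means a weaker inhibitor, a lower number a stronger inhibitor), the three measured compounds stand as follows:

Compound 1, `NC(=O)NC(=O)c1cccc(NC(=O)CBr)c1`, gives 725 nM.
Compound 2, `Cc1cc(/C=C/C(=O)NC(N)=O)cc(NC(=O)C(C)Br)c1`, gives 4820 nM.
Compound 3, `Cc1cc(/C=C/C(=O)NC(N)=O)cc(NC(=O)CCl)c1`, gives 8770 nM.

Compound 1 has the lowest number of the three in this assay. Its nearest neighbour is compound 2, whose value lies beyond the scatter from it, and compound 3 lies further still. Within the data shown here, the one step between compounds that differ in a single place, a 1.8-fold higher number from compound 2 to compound 3 (0.26 log units; within the scatter), concerns the haloacyl group and stays within the scatter.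

Compound 4, `CNC(=O)NC(=O)c1cccc(NC(=O)CBr)c1`, differs from compound 1 by methyl in place of hydrogen on an amide-type nitrogen. Among the measured compounds shown here, no measured step touches this nitrogen: the only step in the set, from compound 2 to compound 3, changes a different part of the molecule, and compounds 2 and 3 also carry a different linker to the acylurea than compound 1. For the measured compounds named here, there is therefore no measured step that bears on the change from compound 1 to compound 4, and the expectation can rest only on the general observation that the one small substituent change in this set moved the number by no more than the scatter. Compound 4 is therefore expected to show a step of a 1.2-fold higher number from compound 1 to compound 4 (0.09 log units; within the scatter), that is, no change beyond the scatter. The estimate for compound 4 is 900 nM, with a range from 350 nM to 2500 nM.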

Compound 4, half-maximal inhibitory concentration: 3160 nM
Beside the measured number, compound 4's estimate is 3.5-fold (0.55 log units) below it, and the stated range ends below it.
By their numbers in this assay, from the lowest: compound 1; then compounds 4, 2 and 3 (each within the scatter of the next, the first and the last beyond it).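

In this assay, methyl in place of hydrogen on the amide-type nitrogen gives a 4.4-fold higher number from compound 1 to compound 4 (0.64 log units; beyond the scatter) and so moves the number by a modest amount. This nitrogen is therefore not indifferent to substitution: even a change of a single heavy atom, one carbon that brings no ring and no charge, is enough to carry the number beyond the scatter. It is also the first step among these compounds to do so, since the only earlier step, a 1.8-fold higher number from compound 2 to compound 3 (0.26 log units; within the scatter) and concerning the haloacyl group, stayed within the scatter and did not touch this nitrogen, and no measured evidence is available to account for the new step.

The compounds shown leave open whether the number would keep rising with an ethyl group or a longer chain on this nitrogen, or whether a hydroxyl group or a methoxy group there would behave differently from methyl. They also leave open whether methyl on the same nitrogen of compound 2 would produce a step of similar size on that different core.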